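A few compounds are considered here, and "the series" means these few. Any claim that something is new, unique, unknown or untested is made for them only; others in the source may bear on it.

Working notes on a pair of fluorinated acid side chains.

Compound 1 `C[C@]1(c2ccc(O)cc2)CSc2cc(O)ccc2[C@H]1CCCCCCCCC(CCCCC(F)(F)C(F)(F)F)C(=O)O` was tested in a functional assay on the whole organism for antagonist activity, with Mus musculus as the target, at a dose of 30 mg/kg by the oral route (on this read-out higher numbers stand for a stronger effect at the one dose given and lower numbers for a weaker effect), and compound 1 gives 97%. Compound 2 `C[C@]1(c2ccc(O)cc2)CSc2cc(O)ccc2[C@H]1CCCCCCCCC(CCCCCC(F)(F)C(F)(F)F)C(=O)O` carries the change 2,2,3,3,3-pentafluoropropyl in place of 1,1,2,2,2-pentafluoroethyl on a saturated chain carbon, five bonds along the chain from a carbonyl carbon on the same core, and in this assay compound 2 gives 94%. The step of a number 3 percentage points lower from compound 1 to compound 2 (within the scatter) shows that this change left the read-out essentially where it was.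

Compound 3 `C[C@]1(c2ccc(O)cc2)CSc2cc(O)ccc2[C@H]1CCCCCCCCCC(CCCC(F)(F)C(F)(F)F)C(=O)O` is built from the same atoms as compound 1, joined differently; the difference between the two cores is not broken down here. In this assay compound 3 gives "not determined" (no result reported), so no number is available for it.

Compound 4 `C[C@]1(c2ccc(O)cc2)CSc2cc(O)ccc2[C@H]1CCCCCCCCCC(CCCCC(F)(F)C(F)(F)F)C(=O)O` stands to compound 3 as compound 2 stands to compound 1, through the change (2,2,3,3,3-pentafluoropropyl in place of 1,1,2,2,2-pentafluoroethyl on a saturated chain carbon, four bonds along the chain from a carbonyl carbon). The two places are not the same word for word: in the first pair the change sits five bonds along the chain from a carbonyl carbon, in the second pair four bonds along the chain from a carbonyl carbon, so this is the same kind of change rather than the same change.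

For compound 4 the expectation in this assay rests on compound 1 at 97% and on the flat step a number 3 percentage points lower from compound 1 to compound 2 (within the scatter); no value for compound 3 is available to anchor it. Compound 4 is therefore expected to give about 92% in this assay, with a range estimated from 78% to 99%.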

Compound 4, a percentage reported as inhibition, in the whole organism at one dose (the size of the read-out at that dose, not a potency): 96%
Estimate against measurement, compound 4: 4 percentage points below; the measured number falls inside the stated range.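

Among these compounds, with no number for compound 3 in this assay, no step from compound 3 to compound 4 can be read. The compounds shown leave open whether 2,2,3,3,3-pentafluoropropyl in place of 1,1,2,2,2-pentafluoroethyl, four bonds along the chain from a carbonyl carbon, leaves the read-out as unchanged as the related change did from compound 1 to compound 2. No supporting data bear on this result.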